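Swapping Fluoro for Bromo on Compound 3

The source may hold more compounds than are shown below. What is called first, only, known or untested is meant among the compounds shown, and "the series" means these compounds.

In a functional assay on CCRF-CEM cells (Homo sapiens) for inhibition (on this read-out higher numbers stand for weaker inhibition and lower numbers for stronger inhibition), compound 1 (`O=C1/C(=C/c2cccc(Cl)c2)Cc2ccccc21`) gives 31800 nM and compound 2 (`Cc1cccc(/C=C2\Cc3ccccc3C2=O)c1`) gives 41300 nM while compound 3 (`O=C1/C(=C/c2ccc(F)cc2)CCc2ccccc21`) gives 33400 nM so all three sit within the scatter of one another. Compound 4 (`O=C1/C(=C/c2ccc(Br)cc2)CCc2ccccc21`) departs from compound 3 in one place (bromo in place of fluoro on an aromatic carbon): bromo in place of fluoro on an aromatic carbon. For the measured compounds named here, no bromo compound has been measured yet. The closest measured step puts methyl in place of chloro on an aromatic carbon of a different core (a 1.3-fold higher number from compound 1 to compound 2 (0.11 log units; within the scatter)) and stays within the scatter. On that evidence, no step beyond the scatter is expected in this assay (a 1.1-fold lower number from compound 3 to compound 4 (0.05 log units; within the scatter)). Compound 4 is estimated at 30000 nM (expected range 15000 nM to 60000 nM).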

Compound 4, half-maximal inhibitory concentration: > 500000 nM
Compound 4 ended at the assay's limit; the forecaster's own chance of this, stated with the estimate: 8%; middle value at least 16-fold (1.22 log units) away from the limit.
By their numbers in this assay, from the lowest: compounds 1, 3 and 2 (each within the scatter of the next). At a limit, above all of these: compound 4.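

Until now every step stayed within the scatter, so the aromatic substituents seemed to matter little. Compound 4 shows that a single change at this position, para to a large group, can matter a great deal: in this assay, bromo in place of fluoro gives an at least 14-fold higher number from compound 3 to compound 4 (1.17 log units; beyond the scatter). Compound 4 stands at a limit of the assay, not at a number: the limit of > 500000 nM in this assay, at which 1 of the 4 values shown sits.

Why bromo and fluoro part so sharply here stays open. So does how a methyl, a chloro or an amine at this position on the core of compound 3 would read.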